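The compounds below may be only part of what the source reports. "The series", "measured", "known", "first", "only" and "open" are said of these compounds alone.

Compound 1 `Cc1cc(Nc2cc(-c3ccccc3)[nH]n2)n2nc(SCc3nc4ccccc4[nH]3)nc2n1` and compound 2 `Cc1cc(Nc2ccn(Cc3nc(C)c4ccccc4n3)n2)n2nc(SCc3ccc(Br)cc3)nc2n1` share a core and differ elsewhere. In a functional assay on MGC-803 cells (Homo sapiens) for inhibition, read by MTT assay, with a stated time of 72 h (on this read-out lower numbers stand for stronger inhibition and higher numbers for weaker inhibition), compound 1 gives 1790 nM, and compound 2 gives 960 nM; the two numbers lie within the scatter of each other, so compound 2 cannot be set apart from compound 1 on these data. Compound 3 `Cc1cc(Nc2ccn(Cc3ccc(F)cc3)n2)n2nc(SCc3ccc(Br)cc3)nc2n1` has not yet been measured in this assay. It differs from compound 2 by 4-fluorophenyl in place of 4-methylquinazolin-2-yl on a saturated chain carbon bound to an aromatic nitrogen. Among the compounds with values here, no measured pair shows this change, so the step from compound 2 to compound 3 is expected to be small, a 1.6-fold higher number from compound 2 to compound 3 (0.19 log units; within the scatter), without a clear direction beyond the scatter. Compound 3 is therefore estimated at 1500 nM, within 500 nM to 5000 nM.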

Compound 3, half-maximal inhibitory concentration: 3070 nM
The estimate for compound 3 lay 2.0-fold (0.31 log units) below the measured number; the range from low to high includes it.
By their numbers in this assay, from the lowest: compounds 2, 1 and 3 (each within the scatter of the next, the first and the last beyond it).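

In this assay, putting 4-fluorophenyl in place of 4-methylquinazolin-2-yl on a saturated chain carbon bound to an aromatic nitrogen gives a 3.2-fold higher number from compound 2 to compound 3 (0.50 log units; beyond the scatter). Within the data shown here, this is the first single-place step available here, and it shows that the read-out responds modestly to the group at this position. Nothing measured here explains the shift. The compounds shown leave open whether the second ring of the group that leaves, its ring nitrogens or its methyl matters, and a pyridin-2-ylmethyl or unsubstituted quinazolin-2-ylmethyl group would help separate these.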